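The source may hold more compounds than are shown below. What is called first, only, known or untested is meant among the compounds shown, and "the series" means these compounds.

Compounds measured in an ADME assay on C8166 cells (Homo sapiens) for cytotoxicity, read by MTT assay; a higher number here means that more compound is tolerated, a lower number that less compound is tolerated:

Compound 1, `Cc1cc(S(N)(=O)=O)ccc1NC(=O)COc1ccc(F)cc1Oc1ccc2cc(Br)ccc2c1`: in this assay compound 1 gives > 357000 nM, which is a limit of the assay rather than a number.
Compound 2, `Cc1cc(S(N)(=O)=O)ccc1NC(=O)COc1ccc(F)cc1Oc1ccc2ccccc2c1Cl`: in this assay compound 2 gives 47100 nM.
Compound 3, `Cc1cc(S(N)(=O)=O)ccc1NC(=O)COc1ccc(F)cc1Oc1c(C)cc2ccccc2c1Cl`: in this assay compound 3 gives 55600 nM.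

Among the two numbers known, compound 3 sits highest, but its nearest neighbour, compound 2, lies within the scatter of it: a 1.2-fold higher number from compound 2 to compound 3 (0.07 log units; within the scatter). Compound 4, `Cc1cc(S(N)(=O)=O)ccc1NC(=O)COc1ccc(F)cc1Oc1ccc2cccc(F)c2c1`, differs from compound 3 in one place: 8-fluoronaphthalen-2-yl in place of 1-chloro-3-methylnaphthalen-2-yl on an oxygen on an aromatic ring. Within the data shown here, the steps that bear on this change are those that move between a naphthalene bearing a halogen on its second ring and one bearing chlorine on the carbon next to the ether oxygen: an at least 7.5-fold lower number from compound 1 to compound 2 (0.87 log units; beyond the scatter) and an at least 6.4-fold lower number from compound 1 to compound 3 (0.80 log units; beyond the scatter). Compound 4 returns to a halogen on the second ring, so the step is expected to run the other way, toward a higher number, by about a 2.9-fold higher number from compound 3 to compound 4 (0.46 log units; beyond the scatter). Compound 4 is therefore estimated at 160000 nM, within 55000 nM to 400000 nM, with a fair chance that this assay reports only a limit for compound 4.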

Compound 4, half-maximal cytotoxic concentration: 171000 nM
For compound 4 the middle estimate is 1.1-fold (0.03 log units) below the measured one; measured number inside the range.
By their numbers in this assay, from the lowest: compounds 2 and 3 (each within the scatter of the next); then compound 4. At a limit, above all of these: compound 1.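

In this assay, 8-fluoronaphthalen-2-yl on an oxygen on an aromatic ring gives a measured number rather than a limit, so its distance from the two 1-chloronaphthalen-2-yl groups can now be sized: a 3.1-fold higher number from compound 3 to compound 4 (0.49 log units; beyond the scatter) and a 3.6-fold higher number from compound 2 to compound 4 (0.56 log units; beyond the scatter). Both steps lie beyond the scatter, and both run toward a higher number. The remaining step runs against a limit rather than a number and reads an at least 2.0-fold lower number from compound 1 to compound 4 (0.31 log units; beyond the scatter), so 8-fluoronaphthalen-2-yl and 6-bromonaphthalen-2-yl are also told apart here: the limit of > 357000 nM in this assay, at which 1 of the 4 values shown sits.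

The compounds shown do not separate the effect of the halogen's identity from that of its place on the naphthalene. Going by these compounds, how a plain naphthalen-2-yl, or one carrying an amine or a carboxylic acid, would read in this assay also remains open.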